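A few compounds are considered here, and "the series" means these few. Any claim that something is new, unique, unknown or untested is made for them only; others in the source may bear on it.

In an ADME assay on MT4 cells (Homo sapiens) for cytotoxicity, read by MTT assay (on this read-out higher numbers stand for lower toxicity in this test and lower numbers for higher toxicity in this test), the three measured compounds give limits only:

- compound 1 `COc1ccc(C(=O)CSc2nc(Cc3c(F)cccc3Cl)cc(=O)[nH]2)cc1` gives > 12000 nM (a limit)
- compound 2 `Cc1c(Cc2c(F)cccc2Cl)nc(SCC(=O)c2ccccc2)[nH]c1=O` gives > 12000 nM (a limit)
- compound 3 `Cc1c(Cc2c(F)cccc2Cl)nc(SCC(=O)c2ccc(F)cc2)[nH]c1=O` gives > 59000 nM (a limit)

Compound 3 stands at > 59000 nM as a limit and not a number. Compound 4 `COc1ccc(C(=O)CSc2nc(Cc3c(F)cccc3Cl)c(C)c(=O)[nH]2)cc1` changes one place of compound 3, and methoxy in place of fluoro on an aromatic carbon is the whole difference, para to a large group. Within the data shown here, the one measured step on that position, a step that the two limits leave unreadable from compound 2 to compound 3, gives no size to carry over. Compound 1, which also bears the 4-methoxyphenyl, gives > 12000 nM as a limit too. No step beyond the scatter is therefore expected in this assay, and no direction. The expected step is an at least 1.9-fold lower number from compound 3 to compound 4 (0.29 log units; that floor lies within the scatter) as estimated from these limits alone. Compound 4 is estimated at 30000 nM within a range of 10000 nM to 90000 nM and is expected to be reported as a limit.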

Compound 4, half-maximal cytotoxic concentration: > 12000 nM
Compound 4 ended at the assay's limit; the forecaster's own chance of this, stated with the estimate: 80%; the middle value does not contradict the limit.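

In this assay compound 4 gives > 12000 nM, a limit and not a number. Its steps from compound 1, compound 2 and compound 3 cannot be read. The compounds shown leave open the size and direction of each of these changes.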